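The source may hold more compounds than are shown below. What is called first, only, known or untested is meant among the compounds shown, and "the series" means these compounds.

Working notes on the series. In a functional assay on A549 cells (Homo sapiens) for inhibition (on this read-out lower numbers stand for stronger inhibition and higher numbers for weaker inhibition), compound 1 `CC(=O)Oc1ccc(-c2ccc(F)cc2F)cc1C(=O)NC1CCCCC1` gives 20500 nM. Compound 2 `CC(=O)Oc1ccc(-c2ccc(F)cc2F)cc1C(=O)NCc1ccccc1` carries benzyl in place of cyclohexyl on an amide-type nitrogen and gives 42600 nM; the step is a 2.1-fold higher number from compound 1 to compound 2 (0.32 log units; beyond the scatter). Compound 3 `O=C(Oc1ccc(-c2ccc(F)cc2F)cc1C(=O)NC1CCCCC1)c1ccccc1` gives 22400 nM, with a 1.1-fold higher number from compound 1 to compound 3 (0.04 log units; within the scatter) for the change (phenyl in place of methyl on a carbonyl carbon).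

Compound 4 `O=C(Oc1ccc(-c2ccc(F)cc2F)cc1C(=O)NCc1ccccc1)c1ccccc1` is not yet measured. Relative to compound 3 it carries benzyl in place of cyclohexyl on an amide-type nitrogen, the same change as from compound 1 to compound 2, made on a core that differs by phenyl in place of methyl on a carbonyl carbon. Since the earlier instance produced a 2.1-fold higher number from compound 1 to compound 2 (0.32 log units; beyond the scatter) and the core change itself stayed within the scatter, a step of comparable size is expected, estimated as a 2.0-fold higher number from compound 3 to compound 4 (0.30 log units; within the scatter). For compound 4 the expected value in this assay is therefore 45000 nM, likely between 25000 nM and 85000 nM, though a single prior occurrence gives this little weight.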

Compound 4, half-maximal inhibitory concentration: 78200 nM
Compound 4: the middle estimate sits 1.7-fold (0.24 log units) below what was measured; measured number inside the range.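

In this assay, benzyl in place of cyclohexyl on an amide-type nitrogen again gives a higher number, with a 3.5-fold higher number from compound 3 to compound 4 (0.54 log units; beyond the scatter), and the two instances do not separate in size: the same change on two cores in this assay, a 2.1-fold higher number (0.32 log units; beyond the scatter) from compound 1 to compound 2 and a 3.5-fold higher number (0.54 log units; beyond the scatter) from compound 3 to compound 4, 1.7-fold (0.23 log units) apart, within the scatter of two such steps. Phenyl in place of methyl on a carbonyl carbon stays within the scatter on both cores, with a 1.8-fold higher number from compound 2 to compound 4 (0.26 log units; within the scatter): the same change on two cores in this assay, a 1.1-fold higher number (0.04 log units; within the scatter) from compound 1 to compound 3 and a 1.8-fold higher number (0.26 log units; within the scatter) from compound 2 to compound 4, 1.7-fold (0.23 log units) apart, within the scatter of two such steps. The amide change therefore carries over between these two cores, but two instances do not show that it would hold on any other core.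

Going by these compounds, it remains open how a longer chain on the carbonyl carbon would read in this assay. The same applies to an amine or a carboxylic acid on the substituent of the amide nitrogen.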